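The compounds below may be only part of what the source reports. "The series", "measured", "known", "first", "only" and "open" are said of these compounds alone.

In a functional assay on NCI-H460 cells (Homo sapiens) for cytotoxicity, read by sulforhodamine B assay (on this read-out lower numbers stand for stronger inhibition of growth and higher numbers for weaker inhibition of growth), the series keeps one shared core and varies the aryl group on a carbon with a double bond to nitrogen. Compound 1 `CC1=CC[C@@H]([C@@](C)(O)CCCC(C)(C)NC(=S)N/N=C\c2ccc(O)cc2)CC1` gives 1460 nM, compound 2 `CC1=CC[C@@H]([C@@](C)(O)CCCC(C)(C)NC(=S)N/N=C\c2ccc(N(C)C)cc2)CC1` gives 19600 nM, and compound 3 `CC1=CC[C@@H]([C@@](C)(O)CCCC(C)(C)NC(=S)N/N=C\c2ccccc2[N+](=O)[O-])CC1` gives 20600 nM. Compound 3 sits level with compound 2, with a 1.1-fold higher number from compound 2 to compound 3 (0.02 log units; within the scatter), and far from compound 1, with a 14-fold higher number from compound 1 to compound 3 (1.15 log units; beyond the scatter). The other large step is a 13-fold higher number from compound 1 to compound 2 (1.13 log units; beyond the scatter).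

The next change leads to compound 4 `CC1=CC[C@@H]([C@@](C)(O)CCCC(C)(C)NC(=S)N/N=C\c2ccc(Cl)cc2)CC1`: 4-chlorophenyl in place of 2-nitrophenyl on a carbon with a double bond to nitrogen. Among the measured compounds shown here, no measured compound carries 4-chlorophenyl, so the three steps bear on it only indirectly. They show that a change of aryl group can produce a large step or none beyond the scatter. Compound 3 and compound 2 share the high end of the measured span, and only compound 1, at 1460 nM, lies well below them. A moderate fall in the number is therefore expected, with much uncertainty. The expected move is a 2.6-fold lower number from compound 3 to compound 4 (0.41 log units; beyond the scatter). For compound 4 the estimate is 8000 nM, with an expected range of 2200 nM to 26000 nM.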

Compound 4, concentration for 50% growth inhibition: 8720 nM
For compound 4 the middle estimate is 1.1-fold (0.04 log units) below the measured one, within the range that was stated.
By their numbers in this assay, from the lowest: compound 1; then compound 4; then compounds 2 and 3 (each within the scatter of the next).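

In this assay, among the compounds shown here, 4-chlorophenyl on a carbon with a double bond to nitrogen opens a middle level, clear of both 2-nitrophenyl (a 2.4-fold lower number from compound 3 to compound 4 (0.37 log units; beyond the scatter)) and the dimethylamino group (a 2.2-fold lower number from compound 2 to compound 4 (0.35 log units; beyond the scatter)), whereas the earlier compounds showed only a low and a high level. Hydroxy still gives the lowest number of the four (a 6.0-fold higher number from compound 1 to compound 4 (0.78 log units; beyond the scatter)), so chloro recovers only part of the gap between compound 1 and the high pair, compounds 2 and 3. No measurement on these compounds accounts for this order of groups.

The compounds shown leave open how a methoxy group or a primary amine in place of chloro on an aromatic carbon would stand against hydroxy. They also leave open whether a carboxylic acid there would keep the low number of compound 1.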